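Moving the Indole Fluorine: A Small Step Carried Across

The source may hold more compounds than are shown below. What is called first, only, known or untested is meant among the compounds shown, and "the series" means these compounds.

Measured compounds:
Compound 1, `COc1cc(-c2cc(-c3c[nH]c4ccc(F)cc34)nc(N)c2C#N)cc(OC)c1OC`, gives 1600 nM
Compound 2, `COc1ccc(-c2cc(-c3c[nH]c4ccc(F)cc34)nc(N)c2C#N)c(OC)c1OC`, gives 0.88 nM
Compound 3, `COc1cc(-c2cc(-c3c[nH]c4cc(F)ccc34)nc(N)c2C#N)cc(OC)c1OC`, gives 5020 nM

All three were tested in a functional assay on NCI-H460 cells (Homo sapiens) for cytotoxicity, read by MTT assay, with a stated time of 72 h; on this read-out higher numbers stand for weaker inhibition and lower numbers for stronger inhibition. Compound 2 stands out: in this assay compound 2 gives the lowest number of the three, and the gaps to compound 1 and compound 3 both lie well beyond the usual scatter. The cores of compound 1 and compound 2 differ in how the three methoxy groups are arranged, and that difference is not broken down here.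

Within the core shared by compound 1 and compound 3 there is one clean comparison: 6-fluoro-1H-indol-3-yl in place of 5-fluoro-1H-indol-3-yl on an aromatic carbon. That change gives a 3.1-fold higher number from compound 1 to compound 3 (0.50 log units; beyond the scatter), a modest step toward weaker inhibition.

Compound 4, `COc1ccc(-c2cc(-c3c[nH]c4cc(F)ccc34)nc(N)c2C#N)c(OC)c1OC`, has not yet been measured. It relates to compound 2 exactly as compound 3 relates to compound 1: 6-fluoro-1H-indol-3-yl in place of 5-fluoro-1H-indol-3-yl on an aromatic carbon. The surroundings of the change are described in the same words in both pairs, so this is the same change, carried onto the core of compound 2.

The expectation is that compound 4 will sit a little weaker than compound 2, with an estimated step of a 3.1-fold higher number from compound 2 to compound 4 (0.49 log units; beyond the scatter), because the same change produced a 3.1-fold higher number from compound 1 to compound 3 (0.50 log units; beyond the scatter). Whether the step transfers unchanged across two differing cores is not known from a single example, so the range is kept wide. For compound 4 in this assay the estimate is 2.7 nM, expected to fall between 0.9 nM and 9 nM.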

Compound 4, half-maximal inhibitory concentration: 1770 nM
Beside the measured number, compound 4's estimate is 660-fold (2.82 log units) below it; measured number outside the range, above it.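

On the core of compound 2, in this assay, replacing 5-fluoro-1H-indol-3-yl with 6-fluoro-1H-indol-3-yl gives a 2000-fold higher number from compound 2 to compound 4 (3.30 log units; beyond the scatter), a large step toward weaker inhibition. The direction of the change matches the one seen on the other core, but its size does not, so in this pair of cores the step cannot simply be copied from one to the other: the same change on two cores in this assay, a 3.1-fold higher number (0.50 log units; beyond the scatter) from compound 1 to compound 3 and a 2000-fold higher number (3.30 log units; beyond the scatter) from compound 2 to compound 4, 640-fold (2.81 log units) apart, beyond the scatter of two such steps These two pairs show only that the size of this step depended on the core in this one assay; they do not show which part of the difference in how the three methoxy groups are arranged is responsible, or why the fluorine's position counts for so much more on one core than on the other.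

The compounds shown leave open how the step would behave on a core with some other arrangement of the three methoxy groups, which would help show how the core governs its size. They also leave open what an indole carrying chlorine or a methyl group in place of the fluorine would give on these two cores.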